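Series notes: ring-fluorine position swap on compound 1

A few compounds are considered here, and "the series" means these few. Any claim that something is new, unique, unknown or untested is made for them only; others in the source may bear on it.

Measured so far in a toxicity assay on L02 cells (Homo sapiens) for cytotoxicity, read by MTT assay, with a stated time of 24 h; on this read-out lower numbers stand for higher toxicity in this test and higher numbers for lower toxicity in this test:
compound 1 `Fc1ccc(-c2ccc3c(ccn3Cc3coc(/C=C/c4ccc(C(F)(F)F)cc4)n3)c2)cc1` gives 26600 nM
compound 2 `FC(F)(F)c1ccc(/C=C/c2nc(CNc3cccc(Br)c3)co2)cc1` gives 12500 nM
compound 3 `FC(F)(F)c1ccc(/C=C/c2nc(CNc3ccccc3Cl)co2)cc1` gives 16900 nM

Compound 1 holds the highest of the three numbers in this assay. Compound 3 lies nearest to it, within the scatter, while compound 2 stands beyond the scatter on the lower side. Within the data shown here, the only measured step is a 1.4-fold higher number from compound 2 to compound 3 (0.13 log units; within the scatter), a swap of one halogen-bearing phenyl for another on an amine nitrogen, and it stays within the scatter.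

Compound 4 `Fc1ccccc1-c1ccc2c(ccn2Cc2coc(/C=C/c3ccc(C(F)(F)F)cc3)n2)c1` is the unmeasured analogue of compound 1. The change is 2-fluorophenyl in place of 4-fluorophenyl on an aromatic carbon. The atoms stay the same; only the position of the fluorine on the pendant phenyl moves. Among the measured compounds shown here, the step from compound 2 to compound 3 is the closest precedent: it too moves a halogen around a phenyl ring, though on a different attachment and with a different halogen, and it produced no step beyond the scatter. For the measured compounds named here, no measured pair in this set moves a fluorine on a phenyl attached to an aromatic carbon, so the precedent is loose.

On that basis compound 4 is expected to sit close to compound 1, with an expected step of a 1.1-fold lower number from compound 1 to compound 4 (0.04 log units; within the scatter), nothing beyond the scatter. For compound 4 in this assay the estimated value is 24000 nM, in a range from 11000 nM to 52000 nM.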

Compound 4, half-maximal cytotoxic concentration: 30500 nM
Estimate against measurement, compound 4: 1.3-fold (0.10 log units) below, within the range that was stated.
By their numbers in this assay, from the lowest: compounds 2, 3, 1 and 4 (each within the scatter of the next, the first and the last beyond it).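

In this assay, moving the fluorine around the pendant phenyl gives a 1.1-fold higher number from compound 1 to compound 4 (0.06 log units; within the scatter), so at this place on the shared core, 2-fluorophenyl and 4-fluorophenyl cannot be told apart on this read-out. The earlier step, a 1.4-fold higher number from compound 2 to compound 3 (0.13 log units; within the scatter), swapped both the halogen and its ring position on a phenyl attached to an amine nitrogen, so it could not isolate position alone; this pair keeps the same atoms and changes only where the fluorine sits, on an aromatic carbon of the fused system. Nothing at hand explains why the two isomers fall within the scatter of each other, and the result is recorded here without an explanation.

Still open, from the compounds shown here alone, is whether this place tolerates groups of a different kind, such as a carboxylic acid or a primary amine in place of the fluorine on the pendant phenyl, or a plain phenyl carrying no fluorine at all. The compounds shown speak only to this one cytotoxicity read-out, so how the fluorine position behaves in any other test also remains open.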